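Chain extension in a hydroxy-oxindole anilide series

This account rests on a few compounds, and the source may have more. Where it says the series, first, only, none or still open, it means among the compounds named here.

Of the compounds shown here, three have been measured in a functional assay on NCI-H460 cells (Homo sapiens) for antiproliferative activity, read by MTT assay, with a stated time of 48 h; a higher number here means a weaker inhibitor, a lower number a stronger inhibitor. Compound 1 `CCCCCC1(O)C(=O)Nc2ccc(Nc3ccc(Cl)cc3)cc21` gives 40800 nM in this assay. Compound 2 `CCCCCCC1(O)C(=O)Nc2ccc(Nc3ccc(Cl)cc3)cc21`, which carries methyl in place of hydrogen on a saturated chain carbon, five bonds along the chain from a saturated ring carbon, gives 30300 nM in this assay; the step is a 1.3-fold lower number from compound 1 to compound 2 (0.13 log units; within the scatter). Compound 3 `CCCCC1(O)C(=O)Nc2ccc(Nc3ccc(C(F)(F)F)cc3)cc21` gives 12000 nM in this assay, the lowest number of the three; the difference between the core of compound 3 and the core of compound 1 is not broken down here.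

Compound 4 `CCCCCC1(O)C(=O)Nc2ccc(Nc3ccc(C(F)(F)F)cc3)cc21` is not yet measured. It carries methyl in place of hydrogen on a saturated chain carbon, four bonds along the chain from a saturated ring carbon. For the measured compounds named here, this is the same kind of change as the one from compound 1 to compound 2, not the same: there the entering methyl sits five bonds along the chain from a saturated ring carbon, here four bonds along the chain from a saturated ring carbon. Because the earlier step was a 1.3-fold lower number from compound 1 to compound 2 (0.13 log units; within the scatter), only a small step is expected from compound 3 to compound 4, estimated as a 1.2-fold lower number from compound 3 to compound 4 (0.08 log units; within the scatter). Compound 4 is therefore expected to give about 10000 nM in this assay, between 5000 nM and 20000 nM.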

Compound 4, half-maximal inhibitory concentration: 16300 nM
Beside the measured number, compound 4's estimate is 1.6-fold (0.21 log units) below it; the range from low to high includes it.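

In this assay, methyl in place of hydrogen on a saturated chain carbon gives a 1.4-fold higher number from compound 3 to compound 4 (0.13 log units; within the scatter), and this step cannot be told apart from the earlier one on the core of compound 1: the same change on two cores in this assay, a 1.3-fold lower number (0.13 log units; within the scatter) from compound 1 to compound 2 and a 1.4-fold higher number (0.13 log units; within the scatter) from compound 3 to compound 4, 1.8-fold (0.26 log units) apart, within the scatter of two such steps. On these two cores, then, the change stays within the scatter, although the entering methyl sits four bonds along the chain from a saturated ring carbon in one case and five bonds in the other. This single pair does not show that the change would stay as small on other cores, and it does not touch the larger step seen for trifluoromethyl in place of chloro on an aromatic carbon, a 2.5-fold lower number from compound 1 to compound 4 (0.40 log units; beyond the scatter).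

On these data alone, it remains open whether a much longer chain, or a chain carrying an amine or a carboxylic acid, would move the number beyond the scatter. As far as these compounds go, it also remains open whether a nitrile or a methoxy group in place of chloro on that aromatic carbon would give a step of similar size.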